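The source may hold more compounds than are shown below. What is called first, only, known or untested is meant among the compounds shown, and "the series" means these compounds.

Working notes on the series.

Compound 1, `Cc1cc(O)cc(-c2nn(CC#N)cc2-c2ccnc(-c3ccc(Oc4ccccc4)cc3)c2)c1`, and compound 2, `COc1cc(C)cc(-c2nn(CC#N)cc2-c2ccnc(-c3ccc(N(C)C)cc3)c2)c1`, have both been run in a functional assay on K562 cells (Homo sapiens) for cytotoxicity, read by sulforhodamine B assay, with a stated time of 48 h, tested at 0.001 uM; on this read-out lower numbers stand for a stronger effect and higher numbers for a weaker effect at the one concentration tested. Compound 1 gives 63% in this assay, and compound 2 gives 66%; the two numbers lie within the scatter of each other, so neither reading can be set apart from the other.

Compound 3, `Cc1cc(O)cc(-c2nn(CC#N)cc2-c2ccnc(-c3ccc(N(C)C)cc3)c2)c1`, has not yet been measured. Relative to compound 2 it carries the change (hydrogen in place of methyl on an oxygen on an aromatic ring). Among the compounds with values here, no measured pair shows this change on its own, so its size is unknown from the data; the expectation is a step from compound 2 of a number 2 percentage points lower from compound 2 to compound 3 (within the scatter), that is, none beyond the scatter. For compound 3 the expected value in this assay is 64%, with a range from 50% to 78%.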

Compound 3, a percentage reported as activity, at one concentration (the size of the read-out at that concentration, not a potency): 100%
Compound 3: middle estimate off by 36 percentage points, on the low side; measured number outside the range, above it.
By their numbers in this assay, from the lowest: compounds 1 and 2 (each within the scatter of the next); then compound 3.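

Hydrogen in place of methyl on the oxygen gives a number 34 percentage points higher from compound 2 to compound 3 (beyond the scatter) in this assay and so a weaker effect at the one concentration tested, which shows that methoxy to hydroxy is not a neutral change at this position when dimethylamino is present. With hydroxy held fixed, dimethylamino in place of phenoxy gives a number 37 percentage points higher from compound 1 to compound 3 (beyond the scatter) and thus also a weaker effect. No measurement on hand bears on why either change acts as it does.

Open, as far as these compounds go, is whether methoxy to hydroxy has the same size with phenoxy in place of dimethylamino. Also open, from the compounds shown here alone, is whether ethoxy on this oxygen reads like methoxy or like hydroxy.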